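Reversing the Amide Link: Expected Solubility of Compound 4

The source may report more compounds than this note shows. Statements on the series, on what has been measured and on what is new or still open speak of the compounds shown alone.

compound 1 `Cc1nc(N2CCN(C3CCOCC3)CC2)nc2ccc(NC(=O)COc3ccc(Cl)cc3)cc12`: 15000 nM
compound 2 `Cc1nc(N2CCC(NC(=O)C(C)C)CC2)nc2ccc(NC(=O)COc3ccc(Cl)cc3)cc12`: 205000 nM
compound 3 `Cc1nc(N2CCC(N3CCCC3)CC2)nc2ccc(NC(=O)C(C)Oc3ccc(Cl)cc3)cc12`: 272000 nM

In a physicochemical assay for solubility, in phosphate buffer (a higher number here means a more soluble compound, a lower number a less soluble compound), compound 2 gives 205000 nM, the second highest of the three numbers. Compound 3 gives 272000 nM, which lies within the scatter of the number for compound 2. Compound 1, with 15000 nM, sits far below compound 2, beyond the scatter. Compound 4 `Cc1nc(N2CCC(C(=O)NC(C)C)CC2)nc2ccc(NC(=O)COc3ccc(Cl)cc3)cc12` has not yet been measured. It differs from compound 2 in one place: isopropylcarbamoyl in place of (isopropylcarbonyl)amino on a saturated ring carbon. Among the compounds with values here, no pair of measured compounds isolates this change, so the expectation rests on compound 2 alone. Because compound 2 gives 205000 nM, compound 4 is expected to land near that figure. The step of a 1.1-fold lower number from compound 2 to compound 4 (0.06 log units; within the scatter) is expected to be small, within the scatter. The estimate for compound 4 is 180000 nM, with a range from 70000 nM to 450000 nM.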

Compound 4, solubility: 132000 nM
Beside the measured number, compound 4's estimate is 1.4-fold (0.13 log units) above it, within the range that was stated.
By their numbers in this assay, from the lowest: compound 1; then compounds 4, 2 and 3 (each within the scatter of the next, the first and the last beyond it).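

Putting isopropylcarbamoyl in place of (isopropylcarbonyl)amino on the saturated ring carbon gives a 1.6-fold lower number from compound 2 to compound 4 (0.19 log units; within the scatter) in this assay as the read-out. This first pair differing in one place shows that, three ring bonds from the ring nitrogen, these two groups, with the same atoms joined differently, cannot be told apart in this assay here. No evidence on the origin of this result is at hand. The compounds shown leave open whether an amine, a carboxylic acid or a longer chain on this ring carbon would stay within the scatter of compound 2.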